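Urea series at sterol O-acyltransferase: pyrazolyl to triazolyl step

The source may hold more compounds than are shown below. What is called first, only, known or untested is meant among the compounds shown, and "the series" means these compounds.

Measured so far:
Compound 1 `Cc1cc(C)c(NC(=O)N(Cc2cccc(-c3cc[nH]n3)c2)C2CCCCC2)c(C)c1`: 0.12 mg/kg
Compound 2 `CSc1cc(C)nc(SC)c1NC(=O)N(Cc1ccc(N(C)C)cc1)Cc1cccc(-c2cc[nH]n2)c1`: < 0.1 mg/kg
Compound 3 `Cc1cc(C)c(NC(=O)N(Cc2ccc(-n3cccn3)cc2)C2CCCCCC2)c(C)c1`: > 1 mg/kg

In a functional assay on a cell-free system (plasma) with sterol O-acyltransferase, Soat (Rattus norvegicus) as the target (a lower number here means that less compound is needed, a higher number that more compound is needed for the effect), compound 1 gives 0.12 mg/kg. Compound 2 gives < 0.1 mg/kg in this assay, which is a limit of the assay and not a number (the limit of < 0.1 mg/kg in this assay, at which 1 of the 3 values shown sits). Compound 3 gives > 1 mg/kg in this assay, again a limit of the assay and not a number (the limit of > 1 mg/kg in this assay, at which 1 of the 3 values shown sits). Compound 3 thus stands at the weak end of the three values shown, with compound 1 and compound 2 both at lower doses.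

Compound 4 `Cc1cc(C)c(NC(=O)N(Cc2ccc(-n3cncn3)cc2)C2CCCCCC2)c(C)c1` is the next compound and carries the change (1H-1,2,4-triazol-1-yl in place of 1H-pyrazol-1-yl on an aromatic carbon), 1H-1,2,4-triazol-1-yl in place of 1H-pyrazol-1-yl on an aromatic carbon. Among the compounds with values here, no measured pair of this kind exists, so the size of the step rests on the change alone. The step that the limit leaves unreadable from compound 3 to compound 4 is expected to be small, with no direction beyond the scatter, and compound 3 sitting at a limit leaves the direction open. Compound 4 is therefore expected to give 1.5 mg/kg in this assay, with a range from 0.5 mg/kg to 5 mg/kg, and a limit rather than a number is likely.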

Compound 4, dose for half-maximal effect: > 1 mg/kg
Compound 4: a limit, no number; the forecaster's own chance of this, stated with the estimate: 55%; the middle value is on the limit's open side.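

In this assay no step can be read from compound 3 to compound 4, because both values are limits of the assay: the limit of > 1 mg/kg in this assay, at which 2 of the 4 values shown sit.

The compounds shown leave open whether 1H-1,2,4-triazol-1-yl in place of 1H-pyrazol-1-yl changes the dose needed at all, and where either compound lies beyond the limit.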